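Phenyl for methoxymethyl at the end of the chain

The source may hold more compounds than are shown below. What is called first, only, known or untested is meant among the compounds shown, and "the series" means these compounds.

In a functional assay on RAW264.7 cells (Mus musculus) for inhibition, read by Griess assay, with stated times of 1 h and 24 h (on this read-out lower numbers stand for stronger inhibition and higher numbers for weaker inhibition), compound 1 `CCCOc1ccc(C(O)C2OC(=O)c3c(OC)cc(OC)cc32)cc1` reads 9260 nM and compound 2 `CCCCCCOc1ccc(C(O)C2OC(=O)c3c(OC)cc(OC)cc32)cc1` reads 5360 nM. Compound 3 `COCCOc1ccc(C(O)C2OC(=O)c3c(OC)cc(OC)cc32)cc1` stands at > 10000 nM, which is a limit of the assay and not a number.

Compound 4 `COc1cc(OC)c2c(c1)C(C(O)c1ccc(OCc3ccccc3)cc1)OC2=O` departs from compound 3 by phenyl in place of methoxymethyl on a saturated chain carbon bound to an oxygen on an aromatic ring. Put another way, 2-methoxyethoxy becomes benzyloxy.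

Within the data shown here, three measured steps bear on this change: a 1.7-fold lower number from compound 1 to compound 2 (0.24 log units; within the scatter), an at least 1.0-fold higher number from compound 1 to compound 3 (0.03 log units; that floor lies within the scatter) and an at least 1.8-fold higher number from compound 2 to compound 3 (0.27 log units; that floor lies within the scatter). All of them are small, and none carries a phenyl group. Compound 2, at 5360 nM, has a chain end without oxygen, as compound 4 does, and so serves as the closest guide. A modest move towards a lower number is therefore expected. The expected change is an at least 1.6-fold lower number from compound 3 to compound 4 (0.22 log units; that floor lies within the scatter), and it may not clear the scatter. For compound 4 the estimate is 6000 nM, with an expected range of 2500 nM to 14000 nM.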

Compound 4, half-maximal inhibitory concentration: > 10000 nM
Compound 4 gave a limit, no number (the forecaster's own chance of this, stated with the estimate: 20%); middle value at least 1.6-fold (0.22 log units) away from the limit.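

The step from compound 3 to compound 4 cannot be read, because both compounds stand at a limit of the assay and not at a number: the limit of > 10000 nM in this assay, at which 2 of the 4 values shown sit. The result does give an at least 1.8-fold higher number from compound 2 to compound 4 (0.27 log units; that floor lies within the scatter) and an at least 1.0-fold higher number from compound 1 to compound 4 (0.03 log units; that floor lies within the scatter), and neither floor establishes a real difference. What is new is that a chain end without oxygen does not ensure a reading below the limit: compound 1 and compound 2 have such an end and give numbers, whereas compound 4, with phenyl in that place, does not.

From the compounds shown here alone, how far compound 3 and compound 4 lie past the limit remains unknown, so phenyl and methoxymethyl cannot be ranked here. Also open, going by these compounds, is whether an amine, a carboxylic acid or a longer chain at this position would give a step beyond the scatter.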